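Notes on the step to compound 4

A few compounds are considered here, and "the series" means these few. Any claim that something is new, unique, unknown or untested is made for them only; others in the source may bear on it.

In a functional assay on HepG2 cells (Homo sapiens) for cytotoxicity, read by MTT assay, with a stated time of 72 h (on this read-out lower numbers stand for stronger inhibition and higher numbers for weaker inhibition), compound 1 (`CC[S+]([O-])CCCCN=C=S`) gives 5350 nM, compound 2 (`[O-][S+](CCCCN=C=S)c1ccccc1`) gives 6340 nM and compound 3 (`[O-][S+](CCCN=C=S)Cc1ccccc1`) gives 9840 nM. Compound 3 lies within the scatter of both others, so the three values show no separable order. Compound 4 (`[O-][S+](CCCCCCN=C=S)Cc1ccccc1`) differs from compound 3 by a group of 6 heavy atoms (4 carbon, 1 nitrogen, 1 sulfur; no ring) in place of a group of 3 heavy atoms (1 carbon, 1 nitrogen, 1 sulfur; no ring), on a saturated chain carbon, three bonds along the chain from a sulfur. Among the measured compounds shown here, no measured pair isolates a single change, so the expectation rests only on how close together these values sit, with compound 3 at 9840 nM. No shift beyond the scatter is expected, only a small drift toward lower numbers. The expected step is a 1.5-fold lower number from compound 3 to compound 4 (0.18 log units; within the scatter), within the scatter. For compound 4 the estimated value is 6500 nM, with an expected range of 3000 nM to 13000 nM.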

Compound 4, half-maximal inhibitory concentration: 6170 nM
Compound 4: middle estimate off by 1.1-fold (0.02 log units), on the high side; the range from low to high includes it.
By their numbers in this assay, from the lowest: compounds 1, 4, 2 and 3 (each within the scatter of the next).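

Among the compounds shown here, this is the first step that changes one place: in this assay, a group of 6 heavy atoms (4 carbon, 1 nitrogen, 1 sulfur; no ring) in place of a group of 3 heavy atoms (1 carbon, 1 nitrogen, 1 sulfur; no ring) gives a 1.6-fold lower number from compound 3 to compound 4 (0.20 log units; within the scatter). At this place, on a saturated chain carbon, three bonds along the chain from a sulfur, the change does not separate the two compounds. No measurement offers an explanation for this result.

On these data alone, whether a longer chain would separate from compound 3 remains open. So does the outcome of an amine or a carboxylic acid in place of the group of 6 heavy atoms.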